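Methyl ester of the piperidine acid: cytotoxicity outlook

The compounds below may be only part of what the source reports. "The series", "measured", "known", "first", "only" and "open" are said of these compounds alone.

Compound 1 `Cc1ccc(-c2nc3ccccc3s2)cc1NC(=O)c1cc([N+](=O)[O-])c(N2CCC(C(=O)O)CC2)cc1Cl`: in an ADME assay on BJ cells (Homo sapiens) for cytotoxicity, with a stated time of 72 h (a lower number here means that less compound is needed, a higher number that more compound is needed for the effect), compound 1 gives > 25000 nM, which is a limit of the assay and not a number.
Compound 2 `COc1ccc(-c2nc3ccccc3s2)cc1NC(=O)c1cc([N+](=O)[O-])c(N2CCC(C(=O)O)CC2)cc1Cl`: in this assay compound 2 gives > 25000 nM, again only a limit.
Compound 3 `O=C(Nc1ccc(Cl)c(C(F)(F)F)c1)c1cc([N+](=O)[O-])ccc1Cl`: in this assay compound 3 gives > 27000 nM, again only a limit.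

Compound 1 therefore stands at a limit, with no number of its own; the limit of > 25000 nM in this assay, at which 2 of the 3 values shown sit, and the limit of > 27000 nM in this assay, at which 1 of the 3 values shown sits, hold all three values. Going by the values given here, the one step between measured compounds, a step that the two limits leave unreadable from compound 1 to compound 2, is unreadable for the same reason. Compound 4 `COC(=O)C1CCN(c2cc(Cl)c(C(=O)Nc3cc(-c4nc5ccccc5s4)ccc3C)cc2[N+](=O)[O-])CC1` differs from compound 1 by methyl in place of hydrogen on an oxygen next to a carbonyl group. Among the compounds with values here, no measured step touches this oxygen, so no direction is expected beyond the scatter. Compound 4 is estimated at 25000 nM, between 8000 nM and 60000 nM, an expected step of a number no higher from compound 1 to compound 4 (the limit leaves the size open), most likely reported again as a limit.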

Compound 4, half-maximal effective concentration: > 25000 nM
Compound 4: a limit, no number (the forecaster's own chance of this, stated with the estimate: 70%); the middle value lies on the limit itself.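

Compound 1 and compound 4 each give only a limit, not a number, and the step between them cannot be read. The compounds shown leave open what concentration of any of them would reach the half-maximal effect in this assay.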